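Aryl sulfonyl swap on the ether-linked amidine series

This account rests on a few compounds, and the source may have more. Where it says the series, first, only, none or still open, it means among the compounds named here.

Among the measured compounds shown here, compound 1 `CN(Cc1ccc(C2=NCCN2)cc1)C(=O)COCCN(C)S(=O)(=O)c1ccccc1C#N` is the reference point of the three compounds measured so far in an ADME assay on microsomes from liver (Homo sapiens) for metabolic stability, with a stated time of 30 min, tested at 1 uM; on this read-out higher numbers stand for a more stable compound and lower numbers for a less stable compound. In this assay compound 1 gives 87%, the highest number of the three. Compound 2 `COc1cc(C)c(S(=O)(=O)N(C)CCOCC(=O)N2CCC(CN3CCN(C)CC3)CC2)c(C)c1` gives 81% in this assay, a number within the scatter of the figure for compound 1, so the two are not distinguished. Compound 3 `Cc1c(Cl)ccc(S(=O)(=O)N(C)CCCCC(=O)N(C)Cc2ccc(C3=NCCN3)cc2)c1Cl` gives 0% in this assay, a gap to compound 1 that lies well beyond the scatter.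

The next compound, compound 4 `Cc1c(Cl)cccc1S(=O)(=O)N(C)CCOCC(=O)N(C)Cc1ccc(C2=NCCN2)cc1`, keeps the core of compound 1 and differs in one place: 3-chloro-2-methylphenyl in place of 2-cyanophenyl on a sulfonyl sulfur. For the measured compounds named here, no measured pair shows this change on its own, so its effect in this assay has to be judged from the spread of the three numbers above.

Going by the values given here, the expected step from compound 1 to compound 4 in this assay is a number 42 percentage points lower from compound 1 to compound 4 (beyond the scatter), a fall beyond the scatter rather than a flat result, because compound 3, the only other compound carrying a halogenated aryl sulfonyl on this core, gives 0%. On that basis compound 4 is estimated at 45% in this assay, with a range from 15% to 80%. Among the compounds with values here, the range is wide: the chain of compound 3 also differs from that of compound 1, and no measured pair isolates the change on the sulfonyl sulfur.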

Compound 4, percent of the compound remaining: 48%
Beside the measured number, compound 4's estimate is 3 percentage points below it; low and high end bracket the measured number.
By their numbers in this assay, from the lowest: compound 3; then compound 4; then compounds 2 and 1 (each within the scatter of the next).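

In this assay, among the compounds shown here, exchanging 2-cyanophenyl for 3-chloro-2-methylphenyl on a sulfonyl sulfur gives the only one-place step so far, a number 39 percentage points lower from compound 1 to compound 4 (beyond the scatter), with the chain and the rest of the core of compound 1 held fixed. For the compounds shown here, the aryl group on this sulfonyl sulfur therefore matters on its own in this read-out, a point that the spread among the earlier compounds could not establish, since they also differ elsewhere. No measurement shown here bears on what lies behind the step, so it stands as an observed difference without an explanation.

The exchange removes the nitrile and brings in both a chlorine and a methyl group at once, so the compounds shown leave open how much of the step belongs to the loss of the nitrile and how much to either new substituent; an unsubstituted phenyl or a fluorophenyl on the same sulfonyl sulfur would help to separate these contributions. Also open, as far as these compounds go, is whether a step of this size would hold on the longer all-carbon chain of compound 3.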